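The compounds below may be only part of what the source reports. "The series", "measured", "known", "first", "only" and "open" are said of these compounds alone.

In a functional assay on SW480 cells (Homo sapiens) for antiproliferative activity, read by sulforhodamine B assay, with a stated time of 48 h (a lower number here means a stronger inhibitor, a higher number a weaker inhibitor), compound 1 `COc1cccc(C=C(C(=O)/C=C/c2cccc(OC)c2OC)C(=O)/C=C/c2cccc(OC)c2OC)c1OC` gives 590 nM, while compound 2 `COc1cc(C=C(C(=O)/C=C/c2cccc(OC)c2OC)C(=O)/C=C/c2cccc(OC)c2OC)cc(Br)c1O` gives 260 nM, the lower of the two numbers. Compound 3 `COc1cccc(/C=C/C(=O)C(=Cc2ccc(OC)c(OC)c2OC)C(=O)/C=C/c2cccc(OC)c2OC)c1OC` changes compound 2 on a double-bonded chain carbon bound to a double-bonded chain carbon: 2,3,4-trimethoxyphenyl in place of 3-bromo-4-hydroxy-5-methoxyphenyl on a double-bonded chain carbon bound to a double-bonded chain carbon. Among the compounds with values here, the one measured step that bears on this is the modest 2.3-fold lower number from compound 1 to compound 2 (0.36 log units; beyond the scatter), where the 3-bromo-4-hydroxy-5-methoxyphenyl group replaced 2,3-dimethoxyphenyl. Losing that group should therefore reverse much of this gain in this assay, so the expected change is a 1.9-fold higher number from compound 2 to compound 3 (0.28 log units; within the scatter). For compound 3, the estimated value is 500 nM, within an expected range of 220 nM to 1100 nM.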

Compound 3, half-maximal inhibitory concentration: 560 nM
For compound 3 the middle estimate is 1.1-fold (0.05 log units) below the measured one, and the stated range covers the measured number.
By their numbers in this assay, from the lowest: compound 2; then compounds 3 and 1 (each within the scatter of the next).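

In this assay, 2,3,4-trimethoxyphenyl at this place does not keep the lower number seen with 3-bromo-4-hydroxy-5-methoxyphenyl (a 2.2-fold higher number from compound 2 to compound 3 (0.33 log units; beyond the scatter)). Methoxy in place of hydrogen on an aromatic carbon makes no difference beyond the scatter (a 1.1-fold lower number from compound 1 to compound 3 (0.02 log units; within the scatter)), so among these compounds only the bromine-bearing group in compound 2 stands apart. Nothing here gives a reason for this.

Still open, as far as these compounds go, is whether the bromine or the hydroxy group accounts for the lower number in compound 2. Also open, from the compounds shown here alone, is how a ring bearing an amine or a carboxylic acid would compare at this place.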